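Hydroxy to ethoxy: from compound 2 to compound 4

This account rests on a few compounds, and the source may have more. Where it says the series, first, only, none or still open, it means among the compounds named here.

In a functional assay on MDA-MB-468 cells (Homo sapiens) for antiproliferative activity, read by sulforhodamine B assay, with a stated time of 4 days (a lower number here means a stronger inhibitor of growth, a higher number a weaker inhibitor of growth), compound 2 `COc1cc(Cl)c(-c2nc(SCC(=O)NC(C)C)nc3[nH]cc(C#N)c23)cc1O` gives 178 nM and compound 3 `COc1cc(Cl)c(-c2nc(SCC(=O)NC(C)(C)C)nc3[nH]cc(C#N)c23)cc1O` gives 152 nM, two values within the scatter of each other. Compound 1 `CCOc1cc(-c2nc(SCC(=O)NC3CC3)nc3[nH]cc(C#N)c23)c(Cl)cc1OC` gives 23 nM, well under both. Among the measured compounds shown here, compound 2 therefore stands at the upper end of the numbers so far, level with compound 3.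

Compound 4 `CCOc1cc(-c2nc(SCC(=O)NC(C)C)nc3[nH]cc(C#N)c23)c(Cl)cc1OC` differs from compound 2 in one place: ethyl in place of hydrogen on an oxygen on an aromatic ring, which is ethyl in place of hydrogen on an oxygen on an aromatic ring, or hydroxy to ethoxy.

For the measured compounds named here, no measured step isolates this change. Going by the values given here, the only single-place step is a 1.2-fold lower number from compound 2 to compound 3 (0.07 log units; within the scatter), made on a saturated chain carbon bound to an amide-type nitrogen, and it stays within the scatter. Compound 1 already carries the ethoxy, but it also differs from compound 2 in the group on the amide nitrogen, so its gap to compound 2 mixes two changes. Compound 3 at 152 nM shows that one change at that amide end left the number where it was, so much of that gap is tentatively assigned to the ethoxy. A lower number is expected, beyond the scatter.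

For compound 4 the expected step is a 5.1-fold lower number from compound 2 to compound 4 (0.71 log units; beyond the scatter).

Compound 4 is estimated at 35 nM, with an expected range of 14 nM to 90 nM.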

Compound 4, concentration for 50% growth inhibition: 77 nM
The estimate for compound 4 lay 2.2-fold (0.34 log units) below the measured number, and the stated range covers the measured number.
By their numbers in this assay, from the lowest: compound 1; then compounds 4, 3 and 2 (each within the scatter of the next, the first and the last beyond it).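

In this assay, the hydroxy to ethoxy change now stands alone, with the isopropyl on the amide-type nitrogen kept constant: a 2.3-fold lower number from compound 2 to compound 4 (0.36 log units; beyond the scatter). This is a modest step beyond the scatter, made by ethyl in place of hydrogen on an oxygen on an aromatic ring. The group on the amide-type nitrogen also proves to matter, with the ethoxy kept constant: a 3.3-fold higher number from compound 1 to compound 4 (0.52 log units; beyond the scatter), for isopropyl in place of cyclopropyl. The earlier step at that end, a 1.2-fold lower number from compound 2 to compound 3 (0.07 log units; within the scatter), stayed within the scatter, but it was read with the hydroxy in place and on a different change, so the amide end cannot be treated as silent across the series. Nothing on hand gives a reason for either new step.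

As far as these compounds go, it remains open how a longer chain such as propoxy, or an aminoethoxy group, on that same oxygen would compare with the ethoxy. Also open, from the compounds shown here alone, is whether the hydroxy to ethoxy step keeps its size with cyclopropyl or tert-butyl on the amide-type nitrogen, as it is read here with isopropyl only.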